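Oxamic acid extension of the aminophenyl thioether

The source may hold more compounds than are shown below. What is called first, only, known or untested is meant among the compounds shown, and "the series" means these compounds.

Within the shared core the three measured compounds are compound 1 `COc1ccc(CCCCCCCCOc2ccc(C[S+]([O-])c3cccc(C(=O)O)c3)nc2/C=C/C(=O)O)cc1`, compound 2 `COc1ccc(CCCCCCCCOc2ccc(CSc3cccc(N)c3)nc2/C=C/C(=O)O)cc1` and compound 3 `COc1ccc(CCCCCCCCOc2ccc(C[S+]([O-])c3cccc(N(C)C)c3)nc2/C=C/C(=O)O)cc1`. In an assay for binding affinity to leukotriene B4 receptor 1 (Homo sapiens) (on this read-out higher numbers stand for weaker inhibition and lower numbers for stronger inhibition), compound 1 gives 151 nM, compound 2 gives 34 nM and compound 3 gives 245 nM. Compound 2 therefore stands lowest of the three, and both its steps to the others are beyond the scatter: a 4.4-fold lower number from compound 1 to compound 2 (0.65 log units; beyond the scatter), and a 7.2-fold higher number from compound 2 to compound 3 (0.86 log units; beyond the scatter). By contrast a 1.6-fold higher number from compound 1 to compound 3 (0.21 log units; within the scatter), so the swap of carboxy for dimethylamino on the aromatic ring leaves the number where it was.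

The unmeasured compound 4 `COc1ccc(CCCCCCCCOc2ccc(CSc3cccc(NC(=O)C(=O)O)c3)nc2/C=C/C(=O)O)cc1` carries carboxycarbonyl in place of hydrogen on a nitrogen on an aromatic ring, that is, amino becomes (carboxycarbonyl)amino and 3-aminophenyl becomes 3-((carboxycarbonyl)amino)phenyl. Among the measured compounds shown here, no measured step alters only the substituent on this nitrogen; the two steps that touch compound 2 each change the sulfur group at the same time, so they bear on it only loosely. The step from compound 1 to compound 3 shows that an acid on this aromatic ring and a nitrogen group are interchangeable within the scatter. The expectation for this assay is therefore a small step, a 1.5-fold higher number from compound 2 to compound 4 (0.17 log units; within the scatter), with no direction clearly favoured. Compound 4 is estimated at 50 nM, with a range from 15 nM to 170 nM.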

Compound 4, inhibition constant: 72 nM
Compound 4: middle estimate off by 1.4-fold (0.16 log units), on the low side; low and high end bracket the measured number.
By their numbers in this assay, from the lowest: compound 2; then compound 4; then compounds 1 and 3 (each within the scatter of the next).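

Among the compounds shown here, the first step that alters only the substituent on a nitrogen on an aromatic ring, with the sulfur group left unchanged, reads in this assay as a 2.1-fold higher number from compound 2 to compound 4 (0.33 log units; beyond the scatter). The position therefore accepts carboxycarbonyl, with a modest rise in the number, so this substituent is tolerated here but gives no gain over the plain amino group of compound 2. This isolates the nitrogen substituent as a change that can be read by itself, which the earlier steps around compound 2 could not do, yet nothing at hand offers an explanation for the size or direction of the step.

Open, going by these compounds, is whether acetyl on this nitrogen, which keeps a carbonyl without the carboxylic acid, or the methyl ester of carboxycarbonyl would give a number nearer to that of the amino group or to that of the carboxycarbonyl group. Also open, on these data alone, is how the same nitrogen substituent reads when the thioether sulfur is replaced by sulfinyl, a pairing that would separate the two changes still combined in the steps around compound 2.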